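A few compounds are considered here, and "the series" means these few. Any claim that something is new, unique, unknown or untested is made for them only; others in the source may bear on it.

In a functional assay on CHO cells for inhibition of Gonadotropin-releasing hormone receptor (Homo sapiens) (a lower number here means a stronger inhibitor, a higher number a weaker inhibitor), compound 1 `Cc1cc(-c2c(O)nc3cc(Cl)c(C(=O)Nc4cnsn4)cc3c2OCC[C@H]2CCO2)cc(C)c1C` gives 49 nM. Among the measured compounds shown here, compound 2 `Cc1cc(-c2c(O)nc3cc(Cl)c(C(=O)Nc4cnsn4)cc3c2OCCC2CCCC2)cc(C)c1C` differs from it at a single place, and in this assay compound 2 gives 1150 nM, the higher of the two numbers measured so far. The step of a 23-fold higher number from compound 1 to compound 2 (1.37 log units; beyond the scatter) is large. Compound 3 `Cc1cc(-c2c(O)nc3cc(Cl)c(C(=O)Nc4cnsn4)cc3c2OCCC2COCCN2)cc(C)c1C` carries morpholin-3-yl in place of cyclopentyl on a saturated chain carbon, two bonds along the chain from an oxygen on an aromatic ring. This change puts a ring holding a nitrogen and an oxygen where compound 1 held a ring with one oxygen and compound 2 a ring of carbon only. For the measured compounds named here, the one step at hand, a 23-fold higher number from compound 1 to compound 2 (1.37 log units; beyond the scatter), shows that the carbon-only ring gave a far higher number than the oxygen-containing ring; a ring with hetero atoms is therefore expected to bring the number back down, though how far remains open. The expected step is a 7.7-fold lower number from compound 2 to compound 3 (0.88 log units; beyond the scatter). Compound 3 is estimated at 150 nM, within a range from 30 nM to 700 nM.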

Compound 3, half-maximal inhibitory concentration: 32 nM
The estimate for compound 3 lay 4.7-fold (0.67 log units) above the measured number; low and high end bracket the measured number.
By their numbers in this assay, from the lowest: compounds 3 and 1 (each within the scatter of the next); then compound 2.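

In this assay, replacing cyclopentyl with morpholin-3-yl gives a 36-fold lower number from compound 2 to compound 3 (1.56 log units; beyond the scatter), so the lost activity returns in full even though morpholin-3-yl has more heavy atoms than the group it replaces. Replacing oxetan-2-yl with morpholin-3-yl gives a 1.5-fold lower number from compound 1 to compound 3 (0.19 log units; within the scatter), so at this place on the chain the two rings with hetero atoms cannot be told apart, although only morpholin-3-yl carries a nitrogen and a hydrogen-bond donor, and among these three compounds only the carbon-only ring stands apart. No measurement here explains why the hetero atoms matter.

From the compounds shown here alone, it remains open whether the nitrogen or the oxygen of morpholin-3-yl counts more. A piperidin-3-yl ring, a tetrahydropyran-3-yl ring and a cyclohexyl ring would separate each hetero atom from ring size.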